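Trimming the Side Chain on the Sulfonamide Nitrogen

The source may report more compounds than this note shows. Statements on the series, on what has been measured and on what is new or still open speak of the compounds shown alone.

Measured compounds:
compound 1, `CC(C)[C@H](C(=O)NO)N(CCN=[N+]=[N-])S(=O)(=O)c1ccc(OCCF)cc1`, 4 nM
compound 2, `CC(C)[C@H](C(=O)NO)N(CCn1cc(CCCF)nn1)S(=O)(=O)c1ccc(OCCF)cc1`, 2 nM

Of the compounds shown here, two have been measured in an assay on isolated protein for inhibition of matrix metalloproteinase-9 (Homo sapiens), read by fluorescence, with a stated time of 30 min; a lower number here means a stronger inhibitor, a higher number a weaker inhibitor. Compound 1 gives 4 nM, and compound 2 gives 2 nM. Among the compounds with values here, compound 2 stands at the lowest of the two numbers, but the only step leading to it, a 2.0-fold lower number from compound 1 to compound 2 (0.30 log units; within the scatter), lies within the scatter, so the two compounds are not distinguished by this assay.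

Compound 3, `CC(C)[C@H](C(=O)NO)N(CC#N)S(=O)(=O)c1ccc(OCCF)cc1`, has not been measured. It differs from compound 2 in one place: a group of 2 heavy atoms (1 carbon, 1 nitrogen; no ring) in place of a group of 10 heavy atoms (6 carbon, 3 nitrogen, 1 fluorine; one five-membered aromatic ring with 3 hetero atoms), on a saturated chain carbon bound to a sulfonamide nitrogen. Within the data shown here, the single measured step that touches this part of the molecule is a 2.0-fold lower number from compound 1 to compound 2 (0.30 log units; within the scatter), where a group with no ring gave way to a group with one five-membered aromatic ring without a change beyond the scatter. Among the measured compounds shown here, on that evidence, exchange at this chain position has been tolerated, although only two compounds support it and the cyano group is much smaller than either earlier substituent. A step of a 2.0-fold higher number from compound 2 to compound 3 (0.30 log units; within the scatter) is therefore expected, none beyond the scatter. The estimate for compound 3 is 4 nM, with a range from 1.5 nM to 15 nM.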

Compound 3, half-maximal inhibitory concentration: 0.07 nM
Compound 3: the middle estimate sits 57-fold (1.76 log units) above what was measured; measured number below the stated range.
By their numbers in this assay, from the lowest: compound 3; then compounds 2 and 1 (each within the scatter of the next).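

In this assay, the position on a saturated chain carbon bound to a sulfonamide nitrogen proves to be more than a place where exchange is merely tolerated: cyano gives a 29-fold lower number from compound 2 to compound 3 (1.46 log units; beyond the scatter) against the group with the five-membered aromatic ring, and a 57-fold lower number from compound 1 to compound 3 (1.76 log units; beyond the scatter) against azidomethyl. Compounds 1 and 2 carry groups with quite different heavy-atom counts and are not told apart, a 2.0-fold lower number from compound 1 to compound 2 (0.30 log units; within the scatter), so among these three compounds heavy-atom count alone does not order the numbers, and only the cyano compound stands apart. Nothing available explains why this exchange has so large an effect.

The compounds shown leave open whether the low number in compound 3 belongs to cyano itself or would also appear with a primary amine, a carboxylic acid or a plain methyl group on that chain carbon, and whether a longer chain ending in cyano would hold it. They also leave open whether the same step would appear with a different group in place of the fluoroethoxy-bearing part of the shared core, and whether other matrix metalloproteinases would respond in the same way.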